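The source may hold more compounds than are shown below. What is called first, only, known or untested is meant among the compounds shown, and "the series" means these compounds.

Compound 1, `NC(=O)Cn1c(-c2ccc(Cl)cc2)nc2cccnc21`, carries a 4-chlorophenyl group on the shared core, and in a functional assay on the whole organism with Mus musculus as the target (on this read-out higher numbers stand for an effect only at larger amounts of compound and lower numbers for an effect already at smaller amounts), compound 1 gives 4.1 mg/kg. Compound 2, `Cc1ccc(-c2nc3cccnc3n2CC(N)=O)cc1`, differs from it only by methyl in place of chloro on an aromatic carbon; in this assay compound 2 gives 50.5 mg/kg, so that the step of a 12-fold higher number from compound 1 to compound 2 (1.09 log units; beyond the scatter) is large. Compound 3, `CN(C)C(=O)Cn1c(-c2ccc(Cl)cc2)nc2ccc(Cl)nc21`, has a dimethylated amide and a chloro substituent on its core; the difference between its core and that of compound 1 is not broken down here. In this assay compound 3 gives 1.1 mg/kg, the lowest of the three numbers. Compound 4, `Cc1ccc(-c2nc3ccc(Cl)nc3n2CC(=O)N(C)C)cc1`, is not yet measured and differs from compound 3 by methyl in place of chloro on an aromatic carbon. This is the same kind of change as from compound 1 to compound 2, with the place described one bond further out as 4-chlorophenyl to 4-methylphenyl. Because the earlier step of a 12-fold higher number from compound 1 to compound 2 (1.09 log units; beyond the scatter) was large, the step of an 11-fold higher number from compound 3 to compound 4 (1.04 log units; beyond the scatter) is expected to be of a similar size. The expected value of compound 4 is therefore 12 mg/kg, with a range from 4 mg/kg to 40 mg/kg.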

Compound 4, dose for half-maximal effect: 2.7 mg/kg
For compound 4 the middle estimate is 4.4-fold (0.65 log units) above the measured one; the whole stated range lies above it.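

In this assay the change from 4-chlorophenyl to 4-methylphenyl again moves the number upward, a 2.5-fold higher number from compound 3 to compound 4 (0.39 log units; beyond the scatter), so the direction seen on the core of compound 1 also holds on the core of compound 3. The size of the step does not carry over, and the two cores give clearly different steps: the same change on two cores in this assay, a 12-fold higher number (1.09 log units; beyond the scatter) from compound 1 to compound 2 and a 2.5-fold higher number (0.39 log units; beyond the scatter) from compound 3 to compound 4, 5.0-fold (0.70 log units) apart, beyond the scatter of two such steps

In this series, then, the size of the step on one core cannot simply be transferred to another, but two pairs set no general rule, and compound 1 and compound 3 differ in more than one place, so the result does not show which difference goes with the smaller step. The compounds shown leave open whether the dimethylated amide or the chloro substituent on the core is what goes with the smaller step. They also leave open how methoxy or trifluoromethyl in place of chloro on the phenyl ring would behave on either core.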